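One Stereocentre Redrawn in Compound 4

This account rests on a few compounds, and the source may have more. Where it says the series, first, only, none or still open, it means among the compounds named here.

Measured values in a physicochemical assay for lipophilicity (a higher number here means a more lipophilic compound, a lower number a more polar compound), are:
compound 1 `O=S(=O)(Nc1nccs1)c1ccc2c(c1)OCC[C@H]2c1ccc(C(F)(F)F)cc1-c1nccs1` gives 3.3
compound 2 `O=S(=O)(Nc1nccs1)c1ccc2c(c1)OCC[C@H]2c1ccc(C(F)(F)F)cc1-n1ccnn1` gives 2.3
compound 3 `Cn1nccc1-c1cc(C(F)(F)F)ccc1[C@H]1CCOc2cc(S(=O)(=O)Nc3nccs3)ccc21` gives 2.2

At 2.2 in this assay, compound 3 stands within the scatter of compound 2 and lower than compound 1 by more than the scatter. Compound 4 `Cn1nccc1-c1cc(C(F)(F)F)ccc1[C@@H]1CCOc2cc(S(=O)(=O)Nc3nccs3)ccc21` differs from compound 3 as follows (the two compounds have the same atoms and bonds and differ only in configuration as drawn: 1 of 1 stereo elements differ; a stereocentre at a saturated ring carbon is drawn R in compound 3 and S in compound 4) with nothing leaving and nothing entering. Going by the values given here, the one measured step, a number 1.00 log units lower from compound 1 to compound 2 (beyond the scatter), exchanges 1,3-thiazol-2-yl for 1H-1,2,3-triazol-1-yl, so it does not bear on a change of configuration. Among the compounds with values here, no measured pair here isolates such a change, and the expectation therefore rests on compound 3 at 2.2 alone. The expected change is no change at the digits printed from compound 3 to compound 4 (within the scatter) and no step beyond the scatter is expected in this assay in either direction. For compound 4 the estimate is 2.2, with an expected range from 1.9 to 2.5 awaiting measurement.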

Compound 4, distribution coefficient: 2.2
Estimate against measurement, compound 4: no gap at the digits printed; the measured number falls inside the stated range.
By their numbers in this assay, from the lowest: compounds 3, 4 and 2 (each within the scatter of the next); then compound 1.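

In this assay, going by these compounds alone, redrawing the stereocentre at the saturated ring carbon from R to S gives no change at the digits printed from compound 3 to compound 4 (within the scatter), the first reading of a change of configuration at this position, and it can be read as such: the fact that compounds 3 and 4 differ only in the configuration as drawn. With compound 4 as the reference, 1-methyl-1H-pyrazol-5-yl in place of 1H-1,2,3-triazol-1-yl gives a number 0.10 log units lower from compound 2 to compound 4 (within the scatter). The same group in place of 1,3-thiazol-2-yl gives a number 1.10 log units lower from compound 1 to compound 4 (beyond the scatter).

Going by these compounds, whether the two drawings of the stereocentre also stay this close with 1,3-thiazol-2-yl or 1H-1,2,3-triazol-1-yl on the aromatic carbon remains open. So does what a carboxylic acid or a primary amine in place of the trifluoromethyl would give in this assay, in either configuration.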